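Hydroxyethyl for isopropyl on the benzylic amine

The source may report more compounds than this note shows. Statements on the series, on what has been measured and on what is new or still open speak of the compounds shown alone.

Compound 1 `CC(C)NCc1ccc(-c2c3ncn(CC4(O)CCN(Cc5ccc(-c6ccco6)cc5Cl)CC4)c(=O)c3nn2C)cc1` gives 29.1 nM in an assay on isolated protein for inhibition of ubiquitin carboxyl-terminal hydrolase 7 (Homo sapiens), with stated times of 30 min and 2 h (on this read-out higher numbers stand for weaker inhibition and lower numbers for stronger inhibition), the lower of the two values to hand. Among the measured compounds shown here, compound 2 `Cn1nc2c(=O)n(CC3(O)CCN(Cc4ccc(-c5cnco5)cc4Cl)CC3)cnc2c1-c1ccc(CN)cc1` gives 71.6 nM in this assay, beyond the scatter from compound 1, but it differs in more than one place, so no single step is read from the pair. Compound 3 `Cn1nc2c(=O)n(CC3(O)CCN(Cc4ccc(-c5ccco5)cc4Cl)CC3)cnc2c1-c1ccc(CNCCO)cc1` differs from compound 1 by 2-hydroxyethyl in place of isopropyl on an amine nitrogen. For the measured compounds named here, no measured step matches this change. In this assay the expected step of a 1.3-fold higher number from compound 1 to compound 3 (0.12 log units; within the scatter) is small, tending toward a higher number but probably within the scatter. Compound 3 is expected to give 38 nM, with a range of 15 nM to 95 nM.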

Compound 3, half-maximal inhibitory concentration: 8.2 nM
Estimate against measurement, compound 3: 4.6-fold (0.67 log units) above; the measured number lies below the stated range.
By their numbers in this assay, from the lowest: compound 3; then compound 1; then compound 2.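

In this assay, 2-hydroxyethyl in place of isopropyl gives a 3.5-fold lower number from compound 1 to compound 3 (0.55 log units; beyond the scatter) on an amine nitrogen that carries a saturated chain carbon. The read-out therefore responds to the group on this nitrogen, even where the heavy-atom count stays the same and a hydrogen-bond donor and acceptor enter. Nothing at hand accounts for the step.

As far as these compounds go, whether the terminal hydroxyl or the chain itself carries the step remains open. A 2-methoxyethyl group or a longer chain such as 3-hydroxypropyl on the same nitrogen would bear on this.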